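The source may report more compounds than this note shows. Statements on the series, on what has been measured and on what is new or still open speak of the compounds shown alone.

Measured compounds:
Compound 1, `Clc1ccc(COc2ccccc2/C=C/C(/C=C/c2ccccn2)=N/Oc2ncnc3cc(Cl)ccc23)c(Cl)c1`, in a functional assay on SMMC-7721 cells (Homo sapiens) for inhibition, read by MTT assay, with a stated time of 72 h, tested at 10 uM (a higher number here means a stronger effect of the compound at the concentration tested, a lower number a weaker effect), gives 91.8%.
Compound 2, `Fc1ccccc1COc1ccc(/C=C/C(/C=C/c2ccccn2)=N/Oc2ncnc3cc(Cl)ccc23)cc1`, in this assay gives 91.2%.
Compound 3, `Clc1ccc(COc2ccc(/C=C/C(/C=C/c3ccccn3)=N/Oc3ncnc4ccccc34)cc2)c(Cl)c1`, in this assay gives 89.6%.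

All three compounds share a core and differ in their benzyl ether and in the substituent on the fused ring system. Compound 3 has the smallest of the three figures, yet compound 2 and compound 1 lie within the usual scatter of it, so no ranking among the three can be drawn from these numbers; the three readings are effectively one level.

Compound 4, `Clc1ccc(COc2ccc(/C=C/C(/C=C/c3ccccn3)=N/Oc3ncnc4cc(Cl)ccc34)cc2)c(Cl)c1`, has not yet been measured. It differs from compound 3 in one place: chloro in place of hydrogen on an aromatic carbon. The same chloro substituent on the fused ring system is already present in compound 1 and in compound 2, both of which sit at the same level as compound 3. On that basis no step beyond the scatter is expected; the step from compound 3 to compound 4 in this assay is estimated as a number 0.9 percentage points higher from compound 3 to compound 4 (within the scatter).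

For compound 4 the estimate in this assay is 90.5%, with a range from 82% to 97%.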

Compound 4, a percentage reported as inhibition, at one concentration (the size of the read-out at that concentration, not a potency): 23.6%
Estimate against measurement, compound 4: 66.9 percentage points above; the whole stated range lies above it.
By their numbers in this assay, from the lowest: compound 4; then compounds 3, 2 and 1 (each within the scatter of the next).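

In this assay the change from quinazolin-4-yl to 7-chloroquinazolin-4-yl brings a number 66 percentage points lower from compound 3 to compound 4 (beyond the scatter) so chloro at this place is not a silent change when the benzyl ether carries 2,4-dichlorophenyl. With the chloro held constant, 2,4-dichlorophenyl in place of 2-fluorophenyl brings a number 67.6 percentage points lower from compound 2 to compound 4 (beyond the scatter) which shows that neither change can be read apart from the other in this series. Compound 1 also carries both groups, with its ether attached at a different place on the ring, and gives 91.8% in this assay so the two groups alone do not fix the low level.

Nothing available here bears on why the drop occurs. As far as these compounds go, it also remains open how a fluoro, methoxy or amine group at this place would read with the 2,4-dichlorophenyl ether.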